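Phenyl in place of ethyl on the sulfonyl of compound 2

The source may report more compounds than this note shows. Statements on the series, on what has been measured and on what is new or still open speak of the compounds shown alone.

Compound 2, `CCS(=O)(=O)N(Cc1ccc(-c2cccc(F)c2)cc1)[C@@H](C)C(=O)N[C@H](C#N)CC(N)=O`, was tested in an assay on isolated protein for inhibition of legumain (Homo sapiens), with stated times of 2 min and 60 min (on this read-out higher numbers stand for weaker inhibition and lower numbers for stronger inhibition), and gives 3890 nM. Among the compounds that returned a number, compound 2 stands highest: compound 1, `C[C@@H](C(=O)N[C@H](C#N)CC(N)=O)N(Cc1ccc(-c2cc(F)cc(F)c2)cc1)S(C)(=O)=O`, gives 1360 nM in this assay, a lower number, and the gap between the two lies beyond the usual scatter. Compound 3, `CS(=O)(=O)N(CC(=O)N[C@H](C#N)CC(N)=O)Cc1ccc(-c2cccc(F)c2F)cc1`, reaches only > 10000 nM in this assay, and that is a limit of the method rather than a number; (the limit of > 10000 nM in this assay, at which 1 of the 3 values shown sits). Among the compounds with values here, compound 1 and compound 3 each differ from compound 2 in more than one place, so no single step between measured compounds can be read from them.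

Compound 4, `C[C@@H](C(=O)N[C@H](C#N)CC(N)=O)N(Cc1ccc(-c2cccc(F)c2)cc1)S(=O)(=O)c1ccccc1`, differs from compound 2 in one place: phenyl in place of ethyl on a sulfonyl sulfur. Within the data shown here, no measured pair shows the effect of such a change here. The expectation is therefore a step from compound 2 to compound 4 of a 1.1-fold lower number from compound 2 to compound 4 (0.05 log units; within the scatter), not clearly beyond the scatter in either direction. Compound 4 is thus estimated to give 3500 nM in this assay, within a range from 900 nM to 12000 nM.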

Compound 4, half-maximal inhibitory concentration: > 10000 nM
Compound 4: only a limit was reported (the forecaster's own chance of this, stated with the estimate: 15%); at least 2.8-fold (0.45 log units) between middle value and limit.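

Replacing ethyl with phenyl on the sulfonyl sulfur is not a neutral exchange in this assay: it gives an at least 2.5-fold higher number from compound 2 to compound 4 (0.41 log units; beyond the scatter), and a higher number here means weaker inhibition. Within the data shown here, the earlier compounds offered no single step at this position, so this pair is the first direct sign that the group on the sulfonyl sulfur affects the read-out, and that phenyl is not tolerated as well as ethyl. The full size of the step stays unknown, since the value of compound 4 is a limit of the method and not a number: the limit of > 10000 nM in this assay, at which 2 of the 4 values shown sit.

As far as these compounds go, it remains open whether a propyl chain or a cyclopropyl on the sulfonyl sulfur would behave like the ethyl of compound 2 or like the phenyl of compound 4. From the compounds shown here alone, it is also open whether a phenyl carrying an amine or a carboxylic acid would restore inhibition.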